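The source may report more compounds than this note shows. Statements on the series, on what has been measured and on what is new or still open speak of the compounds shown alone.

In a functional assay on cells (Melanoma cell) for cytotoxicity against Melanoma cell line (Homo sapiens), read by sulforhodamine B assay, with a stated time of 48 h (on this read-out higher numbers stand for weaker inhibition of growth and lower numbers for stronger inhibition of growth), compound 1 (`COc1ccc2c(c1)/C(=C/c1c(-c3ccncc3)nc3sccn13)C(=O)N2C`) gives 5970 nM and compound 3 (`O=C1Nc2ccccc2C1=Cc1c(-c2ccncc2)nc2sccn12`) gives 3270 nM as measured numbers. Compound 2 (`COc1cc2c(cc1C)NC(=O)/C2=C/c1c(OC)nc2sc(C)cn12`) gives 31500 nM as the highest of the three, and its gap to each of the others lies beyond the scatter. Compound 4 (`COc1ccc2c(c1)/C(=C\c1c(OC)nc3sc(C)cn13)C(=O)N2`) is still unmeasured, and hydrogen in place of methyl on an aromatic carbon sums up how it differs from compound 2: hydrogen in place of methyl on an aromatic carbon. Among the compounds with values here, no measured pair shows this change, so the expectation is only a cautious one, starting from the high number of compound 2 and leaning toward the lower numbers of compound 1 and compound 3. A modest step toward a lower number is expected, estimated as a 2.3-fold lower number from compound 2 to compound 4 (0.35 log units; beyond the scatter) in this assay overall. Compound 4 is expected at 14000 nM with an estimated range of 4000 nM to 45000 nM for now.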

Compound 4, concentration for 50% growth inhibition: 3460 nM
The estimate for compound 4 lay 4.0-fold (0.61 log units) above the measured number, and the stated range ends above it.
By their numbers in this assay, from the lowest: compounds 3, 4 and 1 (each within the scatter of the next); then compound 2.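

Hydrogen in place of methyl on this aromatic carbon, ortho to a methoxy group, gives a 9.1-fold lower number from compound 2 to compound 4 (0.96 log units; beyond the scatter) in this assay. This first look at the position shows that this one small change is enough to strengthen growth inhibition beyond the usual scatter, though the finding rests on this single pair. Nothing at hand explains the step. Going by these compounds, whether a chlorine atom, an amine or an ethyl chain at this carbon would give a lower or higher number remains open. On these data alone, whether the same change would have a similar effect on another core also remains open.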